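Replacing 4-nitrophenyl with 3-bromo-4-methoxyphenyl: what to expect

The source may report more compounds than this note shows. Statements on the series, on what has been measured and on what is new or still open speak of the compounds shown alone.

Three related compounds have so far been measured in a functional assay on Caco-2 cells (Homo sapiens) for inhibition, read by MTT assay, with a stated time of 48 h, tested at 10 uM; on this read-out higher numbers stand for more inhibition of growth at the one concentration tested and lower numbers for less inhibition of growth. Compound 1 `Cc1cc(=O)c2c(O)cc(OC/C=C/c3ccccc3)c([C@H]3CCN(C)C[C@H]3O)c2o1` gives 9%, and compound 2 `Cc1cc(=O)c2c(O)cc(OCc3ccco3)c([C@H]3CCN(C)C[C@H]3O)c2o1` gives 17%. Compound 3 `Cc1oc2c([C@H]3CCN(C)C[C@H]3O)c(O)cc(O)c2c(=O)c1C(O)c1ccc([N+](=O)[O-])cc1` gives 5%, a number within the scatter of compound 1 and beyond the scatter below compound 2.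

The next candidate, compound 4 `COc1ccc(C(O)c2c(C)oc3c([C@H]4CCN(C)C[C@H]4O)c(O)cc(O)c3c2=O)cc1Br`, keeps the structure of compound 3 except for one group: 3-bromo-4-methoxyphenyl in place of 4-nitrophenyl on a saturated chain carbon bound to an aromatic carbon and an oxygen on a saturated carbon. In words, 3-bromo-4-methoxyphenyl stands in place of 4-nitrophenyl on a saturated chain carbon bound to an aromatic carbon and an oxygen on a saturated carbon.

Among the measured compounds shown here, no measured step makes this exchange. For the measured compounds named here, the only single-place step available is a number 8 percentage points higher from compound 1 to compound 2 (within the scatter). It swaps a different group at a different place, so it serves only as a rough guide to how far one exchange can move the number in these compounds. On that thin evidence, no step beyond the scatter is expected in this assay. The step expected is a number 3 percentage points higher from compound 3 to compound 4 (within the scatter). Three measured compounds are little to go on, so the range is kept wide. Compound 4 is estimated at 8%, with an expected range from 1% to 20%.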

Compound 4, percent growth inhibition at one concentration: 0%
The estimate for compound 4 lay 8 percentage points above the measured number, outside the stated range (below it).
By their numbers in this assay, from the lowest: compounds 4, 3, 1 and 2 (each within the scatter of the next, the first and the last beyond it).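

In this assay, placing 3-bromo-4-methoxyphenyl in place of 4-nitrophenyl on a saturated chain carbon bound to an aromatic carbon and an oxygen on a saturated carbon gives a number 5 percentage points lower from compound 3 to compound 4 (within the scatter). Among the compounds shown here, this is the first step read at this place on the shared core, and it shows that the two groups cannot be told apart here, although they have different atoms: the group that leaves has a nitrogen and two oxygens beyond its carbons, while the one that enters has a bromine and an oxygen. Nothing measured here explains the result, so the reason for it stays unknown.

As far as these compounds go, the comparison covers only these two substituted phenyl groups, so it remains open whether a phenyl ring carrying an amine or a carboxylic acid, or a longer saturated carbon chain in place of the ring, would give a step beyond the scatter at this place. The read-out also comes from a single concentration, and whether the two compounds would still match at other concentrations remains an open question.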